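The source may hold more compounds than are shown below. What is called first, only, known or untested is meant among the compounds shown, and "the series" means these compounds.

In a functional assay on L1210 cells (Mus musculus) for inhibition (on this read-out higher numbers stand for an effect only at larger amounts of compound and lower numbers for an effect already at smaller amounts), compound 3 `Cc1cccc(CSc2nc(N)nc3c2ncn3[C@H]2C[C@H](O)[C@@H](CO)O2)n1` gives 31 uM, at the upper end of the series, and compound 1 `CSc1nc(N)nc2c1ncn2[C@H]1C[C@H](O)[C@@H](CO)O1` gives 24 uM, with a 1.3-fold higher number from compound 1 to compound 3 (0.11 log units; within the scatter). Compound 2 `C=CCSc1nc(N)nc2c1ncn2[C@H]1C[C@H](O)[C@@H](CO)O1` gives 3 uM, and the step back up is a 10-fold higher number from compound 2 to compound 3 (1.01 log units; beyond the scatter).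

Compound 4 `Cn1cnc([N+](=O)[O-])c1Sc1nc(N)nc2c1ncn2[C@H]1C[C@H](O)[C@@H](CO)O1` has 1-methyl-4-nitro-1H-imidazol-5-yl in place of (6-methylpyridin-2-yl)methyl on a sulfur.

All measured steps change the same sulfur substituent, and the other one is an 8.0-fold lower number from compound 1 to compound 2 (0.90 log units; beyond the scatter). Among the compounds with values here, none of the measured compounds carries the entering group, so these steps give only a span, not a direct precedent. A modest move towards a lower number is expected, with the estimated step being a 3.1-fold lower number from compound 3 to compound 4 (0.49 log units; beyond the scatter). For compound 4 the estimate is 10 uM, with an expected range of 2 uM to 40 uM.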

Compound 4, concentration for half-maximal effect: 11 uM
The estimate for compound 4 lay 1.1-fold (0.04 log units) below the measured number; the measured number falls inside the stated range.
By their numbers in this assay, from the lowest: compound 2; then compound 4; then compounds 1 and 3 (each within the scatter of the next).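

In this assay, an aromatic ring on this sulfur need not leave the number where compound 3 stands: with 1-methyl-4-nitro-1H-imidazol-5-yl entering, the series shows a 2.8-fold lower number from compound 3 to compound 4 (0.45 log units; beyond the scatter) and a 2.2-fold lower number from compound 1 to compound 4 (0.34 log units; beyond the scatter). Allyl still gives the lowest number of the four, with a 3.7-fold higher number from compound 2 to compound 4 (0.56 log units; beyond the scatter). No available evidence bears on the reason for these steps.

On these data alone, whether the change follows the nitro group, the five-membered ring or the loss of the chain carbon stays open. As far as these compounds go, how an unsubstituted phenyl, a longer chain or a carboxylic acid on the sulfur would read out also remains open.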